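The source may report more compounds than this note shows. Statements on the series, on what has been measured and on what is new or still open speak of the compounds shown alone.

In an ADME assay on microsomes from liver (Homo sapiens) for metabolic stability, with a stated time of 10 min (a higher number here means that more of the compound is left, a lower number that less of the compound is left), compound 1 `COc1cc(OCc2ccccc2OC)c2cc(-c3cn4nc(OC)sc4n3)oc2c1` gives 82%. In the same assay compound 3 `COc1nn2cc(-c3cc4ccccc4o3)nc2s1` gives 80%. For compound 2 `c1ccc(Sc2nn3cc(-c4cc5ccccc5o4)nc3s2)cc1` the result is "not determined" (no result reported).

In this assay, among the compounds with values here, compound 1 gives the higher of the two numbers known, but compound 3 lies within the usual scatter of it, so the two cannot be told apart. Compound 2 has no result in this assay.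

Compound 4 `COc1cc(OCc2cccc(C#N)c2)c2cc(-c3cn4nc(OC)sc4n3)oc2c1` differs from compound 1 by 3-cyanophenyl in place of 2-methoxyphenyl on a saturated chain carbon bound to an oxygen on an aromatic ring. Within the data shown here, no pair of measured compounds shows a step of this kind, so the expectation rests on compound 1 alone. A small step is expected, slightly downward if at all, and not clearly beyond the scatter. Compound 4 is therefore expected to give 76%, within a range from 58% to 90%, an expected step of a number 6 percentage points lower from compound 1 to compound 4 (within the scatter).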

Compound 4, percent of the compound remaining: 100%
For compound 4 the middle estimate is 24 percentage points below the measured one; measured number outside the range, above it.
By their numbers in this assay, from the lowest: compounds 3 and 1 (each within the scatter of the next); then compound 4.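

In this assay, replacing 2-methoxyphenyl with 3-cyanophenyl on a saturated chain carbon bound to an oxygen on an aromatic ring gives a number 18 percentage points higher from compound 1 to compound 4 (beyond the scatter). This position therefore responds to the group on the ring, even though the number of heavy atoms in the group stays the same. Nothing measured here explains the step. The compounds shown leave open whether adding the nitrile or losing the methoxy matters more, as this single swap does both. On these data alone, how an amine or a carboxylic acid on this ring would behave also remains open.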